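This account rests on a few compounds, and the source may have more. Where it says the series, first, only, none or still open, it means among the compounds named here.

Measured so far:
- compound 1 `CCCCc1cn(-c2ccc(NC(=O)Nc3cc(OC4CCCC4)ccc3C)cc2)nn1`: 140 nM
- compound 2 `CC(C)CC(=O)OCCc1cn(-c2ccc(NC(=O)Nc3ccccc3C(F)(F)F)cc2)nn1`: 400 nM

Both compounds were tested in an assay on isolated protein for inhibition of ATP-dependent RNA helicase DDX3X (Homo sapiens), read by FRET, with stated times of 30 s and 40 min; on this read-out higher numbers stand for weaker inhibition and lower numbers for stronger inhibition. Compound 1 gives 140 nM and stands lowest of the two numbers; compound 2 gives 400 nM, a higher number that lies beyond the usual scatter, so compound 1 inhibits more strongly than compound 2 on this read-out.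

The next compound, compound 3 `CCCCc1cn(-c2ccc(NC(=O)Nc3cc(O)ccc3C)cc2)nn1`, has not yet been measured. It differs from compound 1 in one place: hydrogen in place of cyclopentyl on an oxygen on an aromatic ring. Within the data shown here, no pair of measured compounds shows what this change does. The expectation rests on the structures alone. Removing the cyclopentyl group takes away a sizeable piece of compound 1, and the number for compound 3 is expected to move upward, toward weaker inhibition, by a moderate step of a 3.6-fold higher number from compound 1 to compound 3 (0.55 log units; beyond the scatter) that goes beyond the scatter. Compound 3 is therefore estimated at 500 nM, within a range from 150 nM to 2000 nM.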

Compound 3, half-maximal inhibitory concentration: 490 nM
The estimate for compound 3 lay 1.0-fold (0.01 log units) above the measured number, and the stated range covers the measured number.
By their numbers in this assay, from the lowest: compound 1; then compounds 2 and 3 (each within the scatter of the next).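

Replacing cyclopentyl with hydrogen on the oxygen, which turns cyclopentyloxy into hydroxy, gives a 3.5-fold higher number from compound 1 to compound 3 (0.54 log units; beyond the scatter) in this assay. Among these compounds, this is the first direct reading of this position, since compounds 1 and 2 differ in more than one place and could not isolate any single change; it shows that the group on this oxygen affects the number, yet compound 3 still gives 490 nM, so inhibition does not vanish without the cyclopentyl ring. Nothing available explains the size of this step.

On these data alone, it remains open whether a small methyl group on the same oxygen would leave the number closer to that of compound 1 or of compound 3. A longer chain or a phenyl ring there could also push it either way.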